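Fluoroalkyl chain change on compound 1: half-life outlook

The source may hold more compounds than are shown below. What is called first, only, known or untested is meant among the compounds shown, and "the series" means these compounds.

Values in an ADME assay, at pH 5; on this read-out lower numbers stand for a shorter-lived compound and higher numbers for a longer-lived compound:
- compound 1 `COc1ccnc(C[S+]([O-])c2nc3cc(OCC(F)(F)F)ccc3[nH]2)c1OC`: 7.6 h
- compound 2 `COc1ccnc(C[S+]([O-])c2nc3cc(OCC(F)(F)F)ccc3[nH]2)c1C`: 0.15 h

Of the two measured compounds, compound 1 stands highest at 7.6 h. Compound 3 `COc1ccnc(C[S+]([O-])c2nc3cc(OC(F)(F)C(F)F)ccc3[nH]2)c1OC` carries 1,1,2,2-tetrafluoroethyl in place of 2,2,2-trifluoroethyl on an oxygen on an aromatic ring. Going by the values given here, the only measured step, a 51-fold lower number from compound 1 to compound 2 (1.70 log units; beyond the scatter), is large, but it is a different change, methyl in place of methoxy on an aromatic carbon. Among the compounds with values here, no measured step covers the fluorinated chain. No step beyond the scatter is therefore expected in this assay. The estimated step is a 1.1-fold lower number from compound 1 to compound 3 (0.04 log units; within the scatter). For compound 3 the expected value is 7 h, with an estimated range of 3.5 h to 15 h.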

Compound 3, half-life: 3.6 h
For compound 3 the middle estimate is 1.9-fold (0.29 log units) above the measured one; low and high end bracket the measured number.
By their numbers in this assay, from the lowest: compound 2; then compound 3; then compound 1.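

On the oxygen on an aromatic ring, the fluorinated chain does bear on this assay: 1,1,2,2-tetrafluoroethyl in place of 2,2,2-trifluoroethyl gives a 2.1-fold lower number from compound 1 to compound 3 (0.32 log units; beyond the scatter) as a modest step. The chain change therefore counts as a real but limited shift in half-life at this position. No available data account for this step.

Open, going by these compounds, is how a plain ethyl or a longer chain such as propyl on the same oxygen would read. Also open, on these data alone, is whether this chain change gives a similar step on the core of compound 2.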